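Prenyl homologation on the pyranoquinolinone ether series

The compounds below may be only part of what the source reports. "The series", "measured", "known", "first", "only" and "open" are said of these compounds alone.

Measured compounds:
- compound 1, `CCOc1cc(=O)n(CCCO)c2c1CC(CC=C(C)C)C(C)(C)C2`: in a functional assay on PANC-1 cells (Homo sapiens) for inhibition, read by MTT assay, with a stated time of 24 h, tested at 10 uM (on this read-out higher numbers stand for more inhibition at the one concentration tested (going by the name of the read-out) and lower numbers for less inhibition), compound 1 gives 16.6%
- compound 2, `CC(C)=CCOc1cc(=O)n(CCCO)c2c1CC(CC=C(C)C)C(C)(C)C2`: in this assay compound 2 gives 7.5%
- compound 3, `CC(C)=CCC/C(C)=C/COc1cc(=O)n(CCCO)c2c1CC(CC=C(C)C)C(C)(C)C2`: in this assay compound 3 gives 18.4%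

Compounds 1 and 2 share the core and differ only in the ether chain: methyl in place of 2-methylprop-1-en-1-yl on a saturated chain carbon bound to an oxygen on an aromatic ring. That difference gives a number 9.1 percentage points lower from compound 1 to compound 2 (within the scatter), so the two values are within the scatter of each other and no ordering is drawn from them. Compound 3 against compound 1 shows a number 1.8 percentage points higher from compound 1 to compound 3 (within the scatter), again within the scatter.

Within the data shown here, the one step beyond the scatter is from compound 2 to compound 3: 3-methylbut-2-en-1-yl in place of hydrogen on a saturated chain carbon bound to a double-bonded chain carbon. It gives a number 10.9 percentage points higher from compound 2 to compound 3 (beyond the scatter), a modest gain in inhibition at the single concentration.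

Compound 4, `CCOc1cc(=O)n(CCCO)c2c1CC(C/C=C(\C)CCC=C(C)C)C(C)(C)C2`, has not been measured. Against compound 1 the change is 3-methylbut-2-en-1-yl in place of hydrogen on a saturated chain carbon bound to a double-bonded chain carbon. The place of this change matches the place of the change from compound 2 to compound 3 word for word, so it is the same change applied to compound 1 instead of compound 2. On that single precedent, the expected step is a number 8.4 percentage points higher from compound 1 to compound 4 (within the scatter), set beside a number 10.9 percentage points higher from compound 2 to compound 3 (beyond the scatter); the expectation rests on one pair only, and the two cores on which the change is made differ in the ether chain, which widens the uncertainty. For compound 4 the estimated value in this assay is 25%, expected to fall between 12% and 38%.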

Compound 4, a percentage reported as inhibition, at one concentration (the size of the read-out at that concentration, not a potency): 0.8%
For compound 4 the middle estimate is 24.2 percentage points above the measured one, and the stated range ends above it.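

In this assay, 3-methylbut-2-en-1-yl in place of hydrogen on a saturated chain carbon bound to a double-bonded chain carbon gives a number 15.8 percentage points lower from compound 1 to compound 4 (beyond the scatter). Set beside the earlier step on the other core, the same change does not carry over in size or in direction, so a step read on one of these cores gives no usable forecast for the other: the same change on two cores in this assay, a number 10.9 percentage points higher (beyond the scatter) from compound 2 to compound 3 and a number 15.8 percentage points lower (beyond the scatter) from compound 1 to compound 4, 26.7 percentage points apart, beyond the scatter of two such steps
This does not show why the two steps part, since the two cores differ in the ether chain and each core offers a single pair at a single concentration, and it gives no rule for any third core.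

Still open, going by these compounds, is how the change behaves on a core with a further ether chain, such as a longer saturated chain, which would show whether the direction of the step follows the ether chain in any regular way. Also open is whether an ether chain carrying an amine or a carboxylic acid would shift the inhibition read in this assay at all, as the compounds shown hold only hydrocarbon ether chains.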